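Weighing a Ring Swap on a Ketone Without Numbers

This account rests on a few compounds, and the source may have more. Where it says the series, first, only, none or still open, it means among the compounds named here.

The measured compounds:
- compound 1, `N[C@@H](CCCCCC(=O)c1cocn1)c1ncc(-c2ccccc2F)[nH]1`. In an assay for inhibition of histone deacetylase 8 (Homo sapiens), read by fluorescence, with stated times of 3 h and 60 min (on this read-out higher numbers stand for weaker inhibition and lower numbers for stronger inhibition), compound 1 gives > 1000 nM; this is a limit of the assay and not a number.
- compound 2, `COc1nc2ccccc2cc1-c1cnc([C@@H](N)CCCCCC(=O)c2cc[nH]n2)[nH]1`. In this assay compound 2 gives "not determined" (no result reported).
- compound 3, `COc1nc2ccccc2cc1-c1cnc([C@@H](N)CCCCCC(=O)c2ncc[nH]2)[nH]1`. In this assay compound 3 gives "not determined" (no result reported).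

Compound 3 therefore has no number of its own to stand on. Of the other two entries, one is a limit, (the limit of > 1000 nM in this assay, at which 1 of the 3 values shown sits), and the other carries no result at all. Among the compounds with values here, no pair of measured compounds differs in one place, so no measured step exists to lean on.

Compound 4, `COc1nc2ccccc2cc1-c1cnc([C@@H](N)CCCCCC(=O)c2cnoc2C)[nH]1`, has not been measured. It differs from compound 3 in one place: 5-methyl-1,2-oxazol-4-yl in place of 1H-imidazol-2-yl on a carbonyl carbon. Within the data shown here, with no number for compound 3 and no measured step of this kind, the size and direction of the change cannot be read from the data; the only anchor is that compound 1 reached a limit rather than a number. Compound 4 is expected to lie near 2000 nM, between 300 nM and 15000 nM, with a real chance that it, too, is reported only as a limit.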

Compound 4, half-maximal inhibitory concentration: 5000 nM
The estimate for compound 4 lay 2.5-fold (0.40 log units) below the measured number, within the range that was stated.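

Within the data shown here, compound 3 has no single number in this assay, so compound 4, at 5000 nM, gives no step that can be read. On these data alone, whether 5-methyl-1,2-oxazol-4-yl in place of 1H-imidazol-2-yl on a carbonyl carbon strengthens or weakens inhibition stays open.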